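The compounds below may be only part of what the source reports. "The series", "measured", "known", "first", "only" and "open" are said of these compounds alone.

Compound 1 `Fc1cccc(-c2nc(Nc3ccccc3)c3cc(F)ccc3n2)c1`: 49700 nM
Compound 2 `COc1ccc(Nc2nc(-c3cccc(F)c3)nc3ccc(F)cc23)cc1`: 46800 nM
Compound 3 `Fc1cccc(-c2nc(Nc3cccc(Cl)c3)c3cc(F)ccc3n2)c1`: > 50000 nM

All three share one core and differ only in the ring on the amine nitrogen. In a functional assay on COLO 205 cells (Homo sapiens) for cytotoxicity, read by MTT assay, with a stated time of 48 h (a lower number here means a stronger inhibitor, a higher number a weaker inhibitor), compound 1 gives 49700 nM and compound 2 gives 46800 nM. For compound 3 this assay reports only a limit, > 50000 nM, not a number (the limit of > 50000 nM in this assay, at which 1 of the 3 values shown sits). Compound 4 `Fc1cccc(-c2nc(Nc3ccccc3Br)c3cc(F)ccc3n2)c1` differs from compound 3 by 2-bromophenyl in place of 3-chlorophenyl on a nitrogen on an aromatic ring. The two measured steps that alter the same ring are a number no lower from compound 1 to compound 3 (the limit leaves the size open) and an at least 1.0-fold higher number from compound 2 to compound 3 (0.02 log units; that floor lies within the scatter), and neither moves the number beyond the scatter. The step of a number no higher from compound 3 to compound 4 (the limit leaves the size open) is therefore expected to be small or absent. Compound 4 is expected to give 50000 nM, within 20000 nM to 120000 nM.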

Compound 4, half-maximal inhibitory concentration: > 50000 nM
Compound 4 was reported as a limit (the forecaster's own chance of this, stated with the estimate: 60%); the middle value sits exactly at the limit.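

In this assay compound 4, like compound 3, is reported only as a limit, so a second halogen-bearing ring on this nitrogen also yields no number: the limit of > 50000 nM in this assay, at which 2 of the 4 values shown sit. The step of an at least 1.0-fold higher number from compound 2 to compound 4 (0.02 log units; that floor lies within the scatter) can be read, and so can the step of a number no lower from compound 1 to compound 4 (the limit leaves the size open). The step from compound 3 to compound 4 cannot be read. On these data alone, whether an amine or a carboxylic acid on this ring would bring the number clearly under the limit stays open. So does how far compound 3 and compound 4 lie past it.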